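The source may hold more compounds than are shown below. What is called first, only, known or untested is meant among the compounds shown, and "the series" means these compounds.

Compound 2 `COc1cccc(NC(=O)CSc2nc(Nc3ccccc3)c3ccccc3n2)c1` gives 19400 nM in a functional assay on NCI-H1975 cells (Homo sapiens) for inhibition, read by MTT assay, with a stated time of 72 h (a lower number here means a stronger inhibitor, a higher number a weaker inhibitor), the highest of the three numbers seen so far. Compound 1 `O=C(CSc1nc(Nc2ccccc2)c2ccccc2n1)Nc1cccc([N+](=O)[O-])c1` gives 17900 nM and compound 3 `O=C(CSc1nc(Nc2ccccc2)c2ccccc2n1)Nc1ccc(F)cc1` gives 16500 nM in this assay, both within the scatter of compound 2. Compound 4 `CCc1ccc(NC(=O)CSc2nc(Nc3ccccc3)c3ccccc3n2)cc1` differs from compound 2 in one place: 4-ethylphenyl in place of 3-methoxyphenyl on an amide-type nitrogen. The three measured steps all swap the group on this same amide-type nitrogen, and each stayed within the scatter: a 1.1-fold higher number from compound 1 to compound 2 (0.03 log units; within the scatter), a 1.1-fold lower number from compound 1 to compound 3 (0.04 log units; within the scatter) and a 1.2-fold lower number from compound 2 to compound 3 (0.07 log units; within the scatter). No change beyond the scatter is therefore expected in this assay for this step either. Compound 4 is estimated at 18000 nM, between 9000 nM and 36000 nM, an expected step of a 1.1-fold lower number from compound 2 to compound 4 (0.03 log units; within the scatter).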

Compound 4, half-maximal inhibitory concentration: 9910 nM
Estimate against measurement, compound 4: 1.8-fold (0.26 log units) above; low and high end bracket the measured number.
By their numbers in this assay, from the lowest: compounds 4, 3, 1 and 2 (each within the scatter of the next).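

In this assay the 4-ethylphenyl group on the amide-type nitrogen gives a 2.0-fold lower number from compound 2 to compound 4 (0.29 log units; within the scatter) and a 1.7-fold lower number from compound 3 to compound 4 (0.22 log units; within the scatter) and a 1.8-fold lower number from compound 1 to compound 4 (0.26 log units; within the scatter) so an ethyl group joins nitro, methoxy and fluoro on this ring with no change beyond the scatter. The step from compound 2 is the widest seen at this nitrogen so far, yet it still lies within the scatter. No evidence on what lies behind these small steps is at hand.

As far as these compounds go, whether an amine, a carboxylic acid or a chain longer than ethyl on this ring would move the number beyond the scatter stays open. The compounds shown also leave open how changes to the shared core would read.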